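The source may report more compounds than this note shows. Statements on the series, on what has been measured and on what is new or still open speak of the compounds shown alone.

Measured so far:
compound 1, `Cc1ccc(C(=O)CSc2nc3ccccc3[nH]2)cc1`, which in a functional assay on HT-29 cells (Homo sapiens) for inhibition, read by flow cytometry, tested at 10 uM (on this read-out higher numbers stand for more inhibition at the one concentration tested (going by the name of the read-out) and lower numbers for less inhibition), gives 40%
compound 2, `O=C(CSc1nc2ccccc2[nH]1)c1ccc(F)cc1`, which in this assay is reported as "not active" (no number reported)

Compound 2 thus has no single number in this assay: it is reported only as not active, while compound 1 gives 40% under the same conditions. Among the compounds with values here, no counted step between the two is recorded, so their values are simply set side by side.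

The next compound, compound 3, `O=C(CSc1nc2ccccc2[nH]1)c1ccc([N+](=O)[O-])cc1`, differs from compound 2 in one place: nitro in place of fluoro on an aromatic carbon. Since compound 2 has no number, no step in this assay can be computed, and nothing shown suggests how large a change to expect in either direction. Compound 3 is therefore estimated near the low end of the read-out, with a wide range: 20%, from 0% to 45%.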

Compound 3, a percentage reported as inhibition, at one concentration (the size of the read-out at that concentration, not a potency): "not active" (no number reported)
No number was reported for compound 3; no gap can be computed for the estimate.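

Compound 3, like compound 2, is reported as not active in this assay, so no step can be read between them, and no other data bear on this result. The compounds shown leave open whether nitro in place of fluoro changes inhibition at all.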